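This account rests on a few compounds, and the source may have more. Where it says the series, first, only, none or still open, it means among the compounds named here.

Measured compounds in a functional assay on cells for positive allosteric modulation of G-protein coupled receptor 68 (Homo sapiens), read by a luciferase reporter and cAMP accumulation, with a stated time of 30 min, at pH 6.8 and pH 8.3, in the presence of a further agent that is not named here; a lower number here means a less potent compound, a higher number a more potent compound, by a factor of ten per unit of this negative logarithm:
compound 1, `Nc1nc(NCc2ccc(F)cc2)nc(-c2ccccc2CO)n1`, gives 3.97
compound 2, `Nc1nc(NCc2ccc(Cl)cc2)nc(-c2ccccc2CO)n1`, gives 5.22
compound 3, `Nc1nc(NCc2ccc(OC3CC3)cc2)nc(-c2ccccc2CO)n1`, gives 5.07

Compound 3 stands second highest of the three numbers. Its nearest neighbour is compound 2, a step of a number 0.15 log units lower from compound 2 to compound 3 (within the scatter) that lies within the scatter; the step of a number 1.10 log units higher from compound 1 to compound 3 (beyond the scatter) from the fluoro compound lies well beyond it, as does a number 1.25 log units higher from compound 1 to compound 2 (beyond the scatter).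

Compound 4, `Nc1nc(NCc2ccc(Oc3ccccc3)cc2)nc(-c2ccccc2CO)n1`, carries a change at the same position: phenyl in place of cyclopropyl on an oxygen on an aromatic ring. Going by the values given here, no measured step covers the exchange of one group on this oxygen for another. Among the compounds with values here, the steps that bear on it only show that replacing fluoro by a larger group at this aromatic carbon gave large gains, while chloro and cyclopropyloxy sat together within the scatter. On that basis a step of a number 0.13 log units higher from compound 3 to compound 4 (within the scatter) in this assay is expected for compound 4, with nothing beyond the scatter foreseen in either direction. Compound 4 is therefore estimated at 5.2, with a range from 4.4 to 6.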

Compound 4, negative logarithm of the antagonist equilibrium constant: 5.19
Estimate against measurement, compound 4: 0.01 log units above, within the range that was stated.
By their numbers in this assay, from the lowest: compound 1; then compounds 3, 4 and 2 (each within the scatter of the next).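

In this assay, going by these compounds alone, the first exchange of one group on the oxygen on an aromatic ring, phenyl in place of cyclopropyl, gave a number 0.12 log units higher from compound 3 to compound 4 (within the scatter) and so brought no separable change, even with 6 heavy atoms entering where 3 left. Phenoxy in place of chloro gave a number 0.03 log units lower from compound 2 to compound 4 (within the scatter) while phenoxy in place of fluoro gave a number 1.22 log units higher from compound 1 to compound 4 (beyond the scatter) so that compound 2, compound 3 and compound 4 now form one group, with only the fluoro compound, compound 1, standing apart from them. Nothing available gives a reason for this result.

Open, as far as these compounds go, is whether an amine, a carboxylic acid or a longer chain on this aromatic carbon would stay with that group or fall towards compound 1. Also open, from the compounds shown here alone, is how a methoxy group would compare on the same carbon.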